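This account rests on a few compounds, and the source may have more. Where it says the series, first, only, none or still open, it means among the compounds named here.

Within the data shown here, compound 2 `NC(=O)c1ccn(-c2cccc(OC(=O)NCCOCCOc3ccccc3)c2)c1` holds, in an assay (brain) for inhibition of Fatty-acid amide hydrolase 1 (Mus musculus), with stated times of 20 min and 15 min (on this read-out higher numbers stand for weaker inhibition and lower numbers for stronger inhibition), the higher of the two numbers measured so far: it gives 23 nM. Among the measured compounds shown here, its only neighbour in the set, compound 1 `NC(=O)c1ccn(-c2cccc(OC(=O)NCCCCCCc3ccccc3)c2)c1`, gives 0.16 nM in this assay, and the single step known, a 140-fold higher number from compound 1 to compound 2 (2.16 log units; beyond the scatter), comes from exchanging one chain for another two bonds along the chain from an amide-type nitrogen. Compound 3 `NC(=O)c1ccn(-c2cccc(OC(=O)NCCOCCOc3ccccc3F)c2)c1` has not yet been measured. It differs from compound 2 by fluoro in place of hydrogen on an aromatic carbon, so the change sits on an aromatic carbon of the six-membered aromatic ring of carbon only, ortho to a large group, and leaves the chain untouched. For the measured compounds named here, no measured step touches that ring; the one step available, a chain exchange, says nothing about adding fluoro there. With nothing to go on, the expectation for this assay is a step no larger than the scatter, in either direction, a 1.2-fold lower number from compound 2 to compound 3 (0.06 log units; within the scatter). Compound 3 is therefore expected to give about 20 nM, with a range between 7 nM and 70 nM.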

Compound 3, inhibition constant: 18 nM
Beside the measured number, compound 3's estimate is 1.1-fold (0.05 log units) above it; the range from low to high includes it.
By their numbers in this assay, from the lowest: compound 1; then compounds 3 and 2 (each within the scatter of the next).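

In this assay, fluoro in place of hydrogen on an aromatic carbon, ortho to a large group, gives a 1.3-fold lower number from compound 2 to compound 3 (0.11 log units; within the scatter) and so places compound 2 and compound 3 within the scatter of each other. Among these compounds, this is the first measured step on this ring, and it shows that phenoxy to 2-fluorophenoxy, at this one carbon and with this chain, does not separate the two compounds on this read-out, whereas the chain exchange that gives a 140-fold higher number from compound 1 to compound 2 (2.16 log units; beyond the scatter) lies well beyond the scatter. Nothing measured here gives a reason for the small size of the fluoro step.

Going by these compounds, a single atom at a single carbon is a narrow test, so it remains open whether chloro, methoxy or trifluoromethyl at the same carbon, or fluoro on another carbon of this ring, would also stay within the scatter of compound 2. On these data alone, it is also open whether the same fluoro would give a step of similar size on the all-carbon chain of compound 1, where the number is far lower.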